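The source may report more compounds than this note shows. Statements on the series, on what has been measured and on what is new or still open speak of the compounds shown alone.

Compound 1, `C[C@H](Oc1cccc(C2CC2)n1)c1c(Cl)ccc(F)c1Cl`, gives 4.9.
Compound 2, `C[C@H](Oc1ccc2ncc(S(=O)(=O)CC(=O)O)c(C3CC3)c2c1)c1c(Cl)ccc(F)c1Cl`, gives 2.5.
Compound 3, `C[C@H](Oc1ccc2ncc(/C=C/C(=O)O)c(-n3ccnc3)c2c1)c1c(Cl)ccc(F)c1Cl`, gives 2.

These three compounds, which share the same core, have been measured in a physicochemical assay for lipophilicity, using the shake flask method; on this read-out lower numbers stand for lower lipophilicity and higher numbers for higher lipophilicity. Compound 3 stands lowest of the three numbers. Its nearest neighbour is compound 2, whose value in this assay lies higher by a gap beyond the usual scatter; compound 1 lies furthest away, higher still and well beyond the scatter. Within the data shown here, no two of the measured compounds differ from each other in a single place, so no step between measured compounds can be taken as a direct guide.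

Compound 4, `Cc1c(/C=C/C(=O)O)cnc2ccc(O[C@@H](C)c3c(Cl)ccc(F)c3Cl)cc12`, has not yet been measured in this assay. It differs from compound 3 in one place: methyl in place of 1H-imidazol-1-yl on an aromatic carbon. Among the measured compounds shown here, with no measured pair showing this change, the expectation for compound 4 rests on the structural change and on where compound 3 stands, at 2, in this assay. The replacement is expected to raise the value from compound 3 to compound 4 by a number 1.00 log units higher from compound 3 to compound 4 (beyond the scatter), a step beyond the scatter. Compound 4 is therefore estimated at 3 in this assay, with a range from 2.4 to 3.6.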

Compound 4, distribution coefficient: 3
For compound 4 middle estimate and measured number coincide at the digits printed; the range from low to high includes it.
By their numbers in this assay, from the lowest: compound 3; then compound 2; then compound 4; then compound 1.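

Among these compounds, the exchange of 1H-imidazol-1-yl for methyl gives the first comparison in this set between compounds that differ in one place only: in this assay, it produces a number 1.00 log units higher from compound 3 to compound 4 (beyond the scatter), with the 2-carboxyethenyl group and the rest of the shared core unchanged. The earlier compounds shown here differ from one another in more than one place, so they could not tie any difference to this aromatic carbon, opposite the ring nitrogen, on its own; this pair shows that the read-out responds to the group held there. No measurement at hand bears on why this exchange has this effect, and the step records only its size and direction.

Among the compounds shown here, with only one exchange at this position, it remains open how an ethyl group, a methoxy group or an amine on this aromatic carbon would stand in this assay. Also open, from the compounds shown here alone, is whether the same exchange would give a similar step with an amide in place of the ortho 2-carboxyethenyl group.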